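Trifluoromethoxy in place of isopropyl on the shared core

The source may hold more compounds than are shown below. What is called first, only, known or untested is meant among the compounds shown, and "the series" means these compounds.

Of the compounds shown here, three on the shared core have been read in an ADME assay on HCT-116 cells (Homo sapiens) for cytotoxicity, read by CellTiter-Glo, with a stated time of 72 h; a lower number here means a stronger inhibitor, a higher number a weaker inhibitor. Compound 1 `CC1CCN(C2CCN(S(=O)(=O)c3ccc(OCc4ccccc4)cc3)CC2)CC1`, with benzyloxy, gives > 5000 nM, which is a limit of the assay. Compound 2 `CCc1ccc(S(=O)(=O)N2CCC(N3CCC(C)CC3)CC2)cc1`, with ethyl, gives > 5000 nM, again a limit. Compound 3 `CC1CCN(C2CCN(S(=O)(=O)c3ccc(C(C)C)cc3)CC2)CC1`, with isopropyl, gives > 5000 nM, also a limit and not a number. Compound 3 therefore has no measured position of its own, and the other two values shown are limits as well: the limit of > 5000 nM in this assay, at which 3 of the 3 values shown sit.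

Compound 4 `CC1CCN(C2CCN(S(=O)(=O)c3ccc(OC(F)(F)F)cc3)CC2)CC1` is not yet measured. Its change is trifluoromethoxy in place of isopropyl on an aromatic carbon of a six-membered aromatic ring of carbon only, para to a large group.

The closest measured changes are a step that the two limits leave unreadable from compound 1 to compound 2 and a step that the two limits leave unreadable from compound 1 to compound 3, both replacing one group on an aromatic carbon. The remaining one is a step that the two limits leave unreadable from compound 2 to compound 3. None of these has a readable size, so they offer no direction and no step beyond the scatter is expected in this assay.

The expected change is a step that the limit leaves unreadable from compound 3 to compound 4. Compound 4 is estimated at 6000 nM, with an expected range of 2500 nM to 15000 nM, and another limit is the likeliest report.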

Compound 4, half-maximal inhibitory concentration: > 5000 nM
Compound 4 was reported as a limit; the forecaster's own chance of this, stated with the estimate: 85%; the middle value is on the limit's open side.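

In this assay compound 4 gives > 5000 nM, a limit and not a number. Its steps from compound 1, compound 2 and compound 3 cannot be read, and all the compounds shown share one reading: the limit of > 5000 nM in this assay, at which 4 of the 4 values shown sit.

The compounds shown leave open how the groups on this aromatic carbon rank, and whether any of them gives a measurable value on the shared core.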